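From Carbamoyl to Carboxy at the Low End

The compounds below may be only part of what the source reports. "The series", "measured", "known", "first", "only" and "open" are said of these compounds alone.

In a physicochemical assay for solubility, at pH 7.4 (a higher number here means a more soluble compound, a lower number a less soluble compound), compound 1 `CCc1ccc(NC(=O)Nc2cc(C)nc3ccccc23)cc1` gives 3300 nM and compound 2 `Cc1cc(NC(=O)Nc2ccc(F)cc2)c2ccccc2n1` gives 3700 nM. Swapping ethyl for fluoro on an aromatic carbon makes a 1.1-fold higher number from compound 1 to compound 2 (0.05 log units; within the scatter). Compound 3 `Cc1cc(NC(=O)Nc2ccc(C(N)=O)cc2)c2ccccc2n1` carries carbamoyl on that carbon and gives 900 nM, the lowest number of the three. Replacing ethyl with carbamoyl gives a 3.7-fold lower number from compound 1 to compound 3 (0.56 log units; beyond the scatter), and replacing fluoro with carbamoyl gives a 4.1-fold lower number from compound 2 to compound 3 (0.61 log units; beyond the scatter).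

Compound 4 `Cc1cc(NC(=O)Nc2ccc(C(=O)O)cc2)c2ccccc2n1` differs from compound 3 only in having hydroxy in place of amino on a carbonyl carbon, which turns carbamoyl to carboxy: hydroxy in place of amino on a carbonyl carbon. For the measured compounds named here, no measured step touches that carbonyl carbon, so the evidence is indirect. Going by the values given here, the two carbamoyl steps show only that a change at this site can move the number beyond the scatter, and they are modest in size. Compound 3 sits at the low end of the series, and the change removes the carbamoyl group common to both of those steps. A step upward of at least similar size is therefore expected, though its size is poorly constrained. The expected change is a 6.7-fold higher number from compound 3 to compound 4 (0.82 log units; beyond the scatter). For compound 4 the estimated value is 6000 nM, with an expected range from 1200 nM to 30000 nM.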

Compound 4, solubility: 9300 nM
For compound 4 the middle estimate is 1.6-fold (0.19 log units) below the measured one, within the range that was stated.
By their numbers in this assay, from the lowest: compound 3; then compounds 1 and 2 (each within the scatter of the next); then compound 4.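

For the compounds shown here, the change of carbamoyl to carboxy gives the first direct reading at this carbonyl carbon: in this assay, hydroxy in place of amino on a carbonyl carbon gives a 10-fold higher number from compound 3 to compound 4 (1.01 log units; beyond the scatter) and counts as a large step, where the earlier steps at this site were modest. The aromatic carbon that carries these groups can now be seen to move the number in both directions, since carbamoyl gave the lowest number of the series while carboxy gives the highest, with a 2.5-fold higher number from compound 2 to compound 4 (0.40 log units; beyond the scatter) for carboxy in place of fluoro and a 2.8-fold higher number from compound 1 to compound 4 (0.45 log units; beyond the scatter) for carboxy in place of ethyl. Nothing available here accounts for this difference between two groups that differ by a single atom.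

As far as these compounds go, whether a methyl ester or an aminomethyl group on that aromatic carbon would stand nearer to compound 3 or to compound 4 remains open. Going by these compounds alone, it also remains open whether the same change from carbamoyl to carboxy gives a step of similar size on any core other than the one these compounds share.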